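Nitro in Place of Methoxy: Expectation for Compound 3

The source may report more compounds than this note shows. Statements on the series, on what has been measured and on what is new or still open speak of the compounds shown alone.

Measured so far:
compound 1 `COc1ccc(/N=C(\N)N=C(N)N)cc1` — > 10000 nM
compound 2 `N=C(N)NC(=N)Nc1ccccc1Cl` — > 10000 nM

In a functional assay on cells for agonist activity at trace amine-associated receptor 5 (Mus musculus), read by BRET and cAMP accumulation, with a stated time of 20 min (on this read-out lower numbers stand for an effect already at smaller amounts and higher numbers for an effect only at larger amounts of compound), compound 1 gives > 10000 nM, which is a limit of the assay and not a number. Compound 2 in this assay gives > 10000 nM, again a limit. Among the compounds with values here, both values sit at the limit of > 10000 nM in this assay, at which 2 of the 2 values shown sit, so compound 1 stands nowhere above or below any companion: it shares the limit with the only other measured compound, and no step between measured compounds exists to learn from.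

Compound 3 `NC(N)=N/C(N)=N/c1ccc([N+](=O)[O-])cc1` awaits measurement. It differs from compound 1 by nitro in place of methoxy on an aromatic carbon. With both measured values at the limit, there is nothing to suggest a step in this assay beyond the usual scatter. Compound 3 is therefore expected to give 15000 nM, within a range from 4000 nM to 60000 nM, and most likely to be reported once more only as a limit. The step that the limit leaves unreadable from compound 1 to compound 3 implied by this estimate is expected to be none beyond the scatter.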

Compound 3, half-maximal effective concentration: > 10000 nM
Compound 3 gave a limit, no number (the forecaster's own chance of this, stated with the estimate: 80%); the middle value lies beyond the limit too.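

No step can be read from compound 1 to compound 3, nitro in place of methoxy, since both results are limits of the assay and not numbers: the limit of > 10000 nM in this assay, at which 3 of the 3 values shown sit.

The compounds shown leave open which change to the shared core, if any, would give a readable number in this assay.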